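The source may hold more compounds than are shown below. What is called first, only, known or untested is meant among the compounds shown, and "the series" means these compounds.

Compound 1 `O=C(CCCc1ccccc1)c1nc2ncccc2o1`: in an assay on HEK-293T cells for inhibition of diacylglycerol lipase-alpha (Homo sapiens), read by colorimetric assay (a lower number here means a stronger inhibitor, a higher number a weaker inhibitor), compound 1 gives 2240 nM.
Compound 2 `CCCCCC(=O)c1nc2ncccc2o1`: in this assay compound 2 gives > 10000 nM, which is a limit of the assay and not a number.

Compound 2 thus sits at the limit of > 10000 nM in this assay, at which 1 of the 2 values shown sits, the weaker end of the two compounds shown. Among the compounds with values here, the only measured step, an at least 4.4-fold higher number from compound 1 to compound 2 (0.64 log units; beyond the scatter), concerns a different change. Compound 3 `CCCCCCCCCC(=O)c1nc2ncccc2o1` differs from compound 2 by butyl in place of hydrogen on a saturated chain carbon, five bonds along the chain from a carbonyl carbon. Within the data shown here, no measured step mirrors this chain extension; since compound 1 with a larger group at this end gives a number (2240 nM), a modest move to a lower number is expected, an at least 1.6-fold lower number from compound 2 to compound 3 (0.22 log units; that floor lies within the scatter), with wide uncertainty. Compound 3 is estimated at 6000 nM, range 1500 nM to 20000 nM.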

Compound 3, half-maximal inhibitory concentration: 74.1 nM
The estimate for compound 3 lay 81-fold (1.91 log units) above the measured number, outside the stated range (below it).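

In this assay, within the data shown here, the saturated chain proves far more sensitive to length than the earlier compounds showed: butyl in place of hydrogen, five bonds along the chain from a carbonyl carbon, gives an at least 130-fold lower number from compound 2 to compound 3 (2.13 log units; beyond the scatter). Compound 2 stands at > 10000 nM, which is a limit and not a number. A phenyl at the chain end is also not needed for a low number, since hexyl in place of phenyl gives a 30-fold lower number from compound 1 to compound 3 (1.48 log units; beyond the scatter).

From the compounds shown here alone, whether a longer chain would lower the number further remains open. So does how a carboxylic acid at the chain end would read here.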